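A Pyridinylethynyl Group Replaces Thiophenyl at the Assay Limit

The source may hold more compounds than are shown below. What is called first, only, known or untested is meant among the compounds shown, and "the series" means these compounds.

Measured so far in an ADME assay on MT4 cells (Homo sapiens) for cytotoxicity, read by XTT assay, with a stated time of 5 days; a lower number here means that less compound is tolerated, a higher number that more compound is tolerated:
compound 1 `CNC(=O)[C@@H](NC(=O)[C@@](O)(CCCN(Cc1ccc(Br)cc1)NC(=O)[C@@H](NC(=O)OC)C(C)(C)C)Cc1ccccc1)C(C)(C)C` gives > 10000 nM
compound 2 `CNC(=O)[C@@H](NC(=O)[C@@](O)(CCCN(Cc1ccc(-c2ccccc2)cc1)NC(=O)[C@@H](NC(=O)OC)C(C)(C)C)Cc1ccccc1)C(C)(C)C` gives > 50000 nM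
compound 3 `CNC(=O)[C@@H](NC(=O)[C@@](O)(CCCN(Cc1ccc(-c2ccsc2)cc1)NC(=O)[C@@H](NC(=O)OC)C(C)(C)C)Cc1ccccc1)C(C)(C)C` gives > 50000 nM

All three entries are limits and not numbers. Compound 3 stands at the limit of > 50000 nM in this assay, at which 2 of the 3 values shown sit, and so shares its place with one other compound. Compound 1 sits instead at the limit of > 10000 nM in this assay, at which 1 of the 3 values shown sits, which is also only a limit.

Compound 4 `CNC(=O)[C@@H](NC(=O)[C@@](O)(CCCN(Cc1ccc(C#Cc2ccccn2)cc1)NC(=O)[C@@H](NC(=O)OC)C(C)(C)C)Cc1ccccc1)C(C)(C)C` is still unmeasured. It differs from compound 3 in one place, on an aromatic carbon of a six-membered aromatic ring of carbon only, para to a large group, where 2-(pyridin-2-yl)ethynyl stands in place of thiophen-3-yl: 2-(pyridin-2-yl)ethynyl in place of thiophen-3-yl on an aromatic carbon.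

Among the measured compounds shown here, three measured steps bear on this change, each an exchange of the group on such an aromatic carbon. They are a step that the two limits leave unreadable from compound 1 to compound 2, a step that the two limits leave unreadable from compound 1 to compound 3 and a step that the two limits leave unreadable from compound 2 to compound 3, so none offers a size to carry over. No direction can be drawn from them for this assay, and no change beyond the usual scatter is expected. The estimated step is a number no higher from compound 3 to compound 4 (the limit leaves the size open) as the expected outcome. Compound 4 is expected near 50000 nM with an estimated range from 15000 nM to 80000 nM. A limit and not a number is also possible for compound 4.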

Compound 4, half-maximal cytotoxic concentration: > 50000 nM
Compound 4 gave a limit, no number; the forecaster's own chance of this, stated with the estimate: 80%; the middle value sits exactly at the limit.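

In this assay, compound 4 gives only a limit, as do compound 1, compound 2 and compound 3, so the steps from each of these three to compound 4 cannot be read. The compounds shown leave open where the half-maximal cytotoxic concentration of any of the four lies, and whether exchanging the group on the aromatic carbon changes it at all.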